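The source may hold more compounds than are shown below. What is called first, only, known or untested is meant among the compounds shown, and "the series" means these compounds.

Measured so far in a functional assay on CHO cells for agonist activity at metabotropic glutamate receptor 5 (Homo sapiens), read by inositol phosphate accumulation; on this read-out higher numbers stand for weaker inhibition and lower numbers for stronger inhibition:
compound 1, `Cc1nc(C#Cc2cncc(-c3ccc(F)cc3)c2)cs1`, gives 162 nM
compound 2, `Cc1nc(C#Cc2cncc(C#CCO)c2)cs1`, gives 68.6 nM
compound 3, `C#Cc1cncc(C#Cc2csc(C)n2)c1`, gives 19.2 nM

Compound 3 stands at the lowest number of the three, and both of its steps lie beyond the scatter: an 8.4-fold lower number from compound 1 to compound 3 (0.93 log units; beyond the scatter) and a 3.6-fold lower number from compound 2 to compound 3 (0.55 log units; beyond the scatter). The remaining pair also changes the same carbon: a 2.4-fold lower number from compound 1 to compound 2 (0.37 log units; beyond the scatter).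

Compound 4, `C=Cc1cncc(C#Cc2csc(C)n2)c1`, differs from compound 3 in one place: vinyl in place of ethynyl on an aromatic carbon. The measured steps that bear on this change are the two in which ethynyl entered at this very carbon, and in both the number went down. Among the measured compounds shown here, no measured step exchanges ethynyl for vinyl, so the direction of this step is not pinned down by a direct precedent. Since compound 4 keeps a group of the same atom count at that carbon, the expectation is a step that is small or within the scatter, if anything toward a higher number: a 1.7-fold higher number from compound 3 to compound 4 (0.22 log units; within the scatter). The estimated value for compound 4 is 32 nM, with a range from 12 nM to 85 nM.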

Compound 4, half-maximal inhibitory concentration: 2.01 nM
Compound 4: middle estimate off by 16-fold (1.20 log units), on the high side, and the stated range ends above it.
By their numbers in this assay, from the lowest: compound 4; then compound 3; then compound 2; then compound 1.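

Among the compounds shown here, at this aromatic carbon, two atoms from the ring nitrogen, heavy-atom count alone does not set the number in this assay: ethynyl and vinyl have the same count, yet exchanging the triple bond for a double bond gives a 9.6-fold lower number from compound 3 to compound 4 (0.98 log units; beyond the scatter), the second-largest gain seen at this position after the earlier steps had favoured ethynyl. Vinyl also outdoes the larger groups at this carbon, with a 34-fold lower number from compound 2 to compound 4 (1.53 log units; beyond the scatter) and an 81-fold lower number from compound 1 to compound 4 (1.91 log units; beyond the scatter), which makes it the best of the four groups shown. Nothing available here explains why the double bond does so much better than the triple bond.

The compounds shown leave open whether this gain is special to vinyl or extends to other small groups at this carbon, such as ethyl, methyl or cyclopropyl. Going by these compounds, whether vinyl keeps its edge when the shared core changes elsewhere also remains open.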